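The compounds below may be only part of what the source reports. "The series", "measured", "known", "first", "only" and "open" are said of these compounds alone.

The measured compounds in an ADME assay on the whole organism with Oryza sativa as the target, tested at 10 uM (a lower number here means a stronger effect, a higher number a weaker effect of the compound at the concentration tested), are:

compound 1, `C[C@H](NC(=O)Nc1cccc(C(F)(F)F)c1)c1ccccc1`, with 92%;
compound 2, `C[C@H](NC(=O)Nc1cccc(F)c1)c1ccccc1`, with 88%;
compound 3, `C[C@@H](NC(=O)Nc1cccc(F)c1F)c1ccccc1`, with 90%.

All three readings of compound 1, compound 2 and compound 3 lie within the usual scatter of one another. The difference between the cores of compound 2 and compound 3 is not broken down here. Compound 2 and compound 1 differ by trifluoromethyl in place of fluoro on an aromatic carbon, a change that gave a number 4 percentage points higher from compound 2 to compound 1 (within the scatter). Compound 4, `C[C@@H](NC(=O)Nc1cccc(C(F)(F)F)c1F)c1ccccc1`, is unmeasured and differs from compound 3 by trifluoromethyl in place of fluoro on an aromatic carbon. The place is here also ortho to a fluoro group, so this is the same kind of change, not the same one. For compound 4 in this assay, a step of about a number 3 percentage points higher from compound 3 to compound 4 (within the scatter) is expected, resting on compound 2 to compound 1 having given a number 4 percentage points higher from compound 2 to compound 1 (within the scatter). Compound 4 is therefore estimated at 93%, expected between 84% and 100%.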

Compound 4, a percentage reported as activity, at one concentration (the size of the read-out at that concentration, not a potency): 98%
Compound 4: middle estimate off by 5 percentage points, on the low side; the range from low to high includes it.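

In this assay, trifluoromethyl in place of fluoro on an aromatic carbon gave a number 8 percentage points higher from compound 3 to compound 4 (within the scatter), and the two cores show no difference that can be told apart in how they take this change: the same change on two cores in this assay, a number 4 percentage points higher (within the scatter) from compound 2 to compound 1 and a number 8 percentage points higher (within the scatter) from compound 3 to compound 4, 4 percentage points apart, within the scatter of two such steps. This supports carrying the change between these two cores in this series. It does not show that the change has a real effect on either core, as neither step rises above the scatter, and it says nothing about cores beyond these.

The four compounds carry only fluoro and trifluoromethyl on this aromatic ring. Going by these compounds, what this assay would read with an amine or a carboxylic acid in that place remains open.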